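This account rests on a few compounds, and the source may have more. Where it says the series, first, only, none or still open, it means among the compounds named here.

Values in a functional assay on U-251 cells (Homo sapiens) for antiproliferative activity, read by MTT assay, with a stated time of 24 h; on this read-out lower numbers stand for stronger inhibition and higher numbers for weaker inhibition:
- Compound 1 `C#CCOc1ccc2c(=O)c(-c3cc(OC)c(OC)cc3OC)coc2c1`: 6450 nM
- Compound 2 `COc1cc(OC)c(-c2coc3cc(OCC(=O)c4cccc(C(F)(F)F)c4)ccc3c2=O)cc1OC`: > 10000 nM, a limit of the assay
- Compound 3 `COc1cc(OC)c(-c2coc3cc(OCc4ccccc4F)ccc3c2=O)cc1OC`: 2890 nM

Within the data shown here, compound 3 holds the lowest number so far, with 2890 nM in this assay, and both of its steps to the other compounds lie beyond the scatter.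

The next compound is compound 4 `COc1cc(OC)c(-c2coc3cc(OCc4ccc(F)cc4)ccc3c2=O)cc1OC`, an isomer of compound 3. The change is 4-fluorophenyl in place of 2-fluorophenyl on a saturated chain carbon bound to an oxygen on an aromatic ring.

Among the measured compounds shown here, three measured steps concern this same place. The step of a 2.2-fold lower number from compound 1 to compound 3 (0.35 log units; beyond the scatter) is modest, and the step of an at least 3.4-fold lower number from compound 2 to compound 3 (0.53 log units; beyond the scatter) is at least modest. The step of an at least 1.5-fold higher number from compound 1 to compound 2 (0.19 log units; that floor lies within the scatter) has a floor within the scatter. These steps show that this assay responds to the group at this place, but each swaps one group for a quite different one. None of them compares two fluorophenyl groups, so they give no direction for this change and only loosely bound its size.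

The estimated step is a 1.1-fold higher number from compound 3 to compound 4 (0.04 log units; within the scatter), and no change beyond the scatter is expected. The range is kept wide on the upper side, towards the value of compound 1 at 6450 nM. The estimate for compound 4 is 3200 nM, with an expected range of 1500 nM to 6800 nM.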

Compound 4, half-maximal inhibitory concentration: 3200 nM
Estimate against measurement, compound 4: no gap at the digits printed, and the stated range covers the measured number.
By their numbers in this assay, from the lowest: compounds 3, 4 and 1 (each within the scatter of the next, the first and the last beyond it). At a limit, above all of these: compound 2.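

In this assay, the swap of 2-fluorophenyl for 4-fluorophenyl on a saturated chain carbon bound to an oxygen on an aromatic ring gives a 1.1-fold higher number from compound 3 to compound 4 (0.04 log units; within the scatter); this first comparison of two fluorophenyl groups shows that, for these two isomers only, the place of the fluorine on the ring makes no readable difference. Measured against the ethynyl group, the 4-fluorophenyl group gives a 2.0-fold lower number from compound 1 to compound 4 (0.30 log units; within the scatter), and measured against the (3-(trifluoromethyl)phenyl)carbonyl group it gives an at least 3.1-fold lower number from compound 2 to compound 4 (0.49 log units; beyond the scatter), so both fluorophenyl isomers sit well clear of that carbonyl-bearing group, while only the 2-fluorophenyl step from the ethynyl group is printed as beyond the scatter. Compound 2 stands at a limit, so every step that involves it is a floor and not a measured size: the limit of > 10000 nM in this assay, at which 1 of the 4 values shown sits.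

Still open, from the compounds shown here alone, is whether a plain phenyl without fluorine, a chlorophenyl or a longer chain between the oxygen and the ring would hold the number at this level. Equally open, going by these compounds, is whether an amine or a carboxylic acid on the ring at this place would move the number beyond the scatter in either direction.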